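Cytotoxicity notes: from compound 1 to compound 3

This account rests on a few compounds, and the source may have more. Where it says the series, first, only, none or still open, it means among the compounds named here.

Compound 1 `COCCOc1nc(N)nc2c1ncn2/C=C1/CC1(CO)CO` is measured in an ADME assay on CCRF-HSB-2 cells (Homo sapiens) for cytotoxicity, with a stated time of 7 days (on this read-out lower numbers stand for higher toxicity in this test and higher numbers for lower toxicity in this test), only as a limit; in that test compound 1 gives > 20000 nM. Compound 2 `CN(C)c1nc(N)nc2c1ncn2/C=C1/CC1(CO)CO` likewise gives only a limit in this assay, > 20000 nM. The step that the two limits leave unreadable from compound 1 to compound 2 therefore cannot be read, because of the limit of > 20000 nM in this assay, at which 2 of the 2 values shown sit. Compound 3 `CC(C)Nc1nc(N)nc2c1ncn2/C=C1/CC1(CO)CO` carries the change (isopropylamino in place of 2-methoxyethoxy on an aromatic carbon). Only the unreadable step from compound 1 to compound 2 bears on it, so no direction beyond the scatter can be foreseen; the step that the limit leaves unreadable from compound 1 to compound 3 is expected to stay within the scatter. Compound 3 is estimated at 30000 nM in this assay, in the range 10000 nM to 100000 nM, most likely again reported as a limit.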

Compound 3, half-maximal cytotoxic concentration: > 20000 nM
Compound 3: only a limit was reported; the forecaster's own chance of this, stated with the estimate: 80%; the middle value lies beyond the limit too.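

For the compounds shown here, no step among compound 1, compound 2 and compound 3 can be read in this assay, because each gives only a limit: the limit of > 20000 nM in this assay, at which 3 of the 3 values shown sit. The compounds shown leave open whether the 2-methoxyethoxy, dimethylamino and isopropylamino groups differ at all in cytotoxicity.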